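Adding a methoxy group to compound 1

This account rests on a few compounds, and the source may have more. Where it says the series, first, only, none or still open, it means among the compounds named here.

Compound 1, `CCCCn1cc(C2CCN(Cc3cccc(C(=O)O)c3)CC2)c2ccccc21`, in an assay on brain for binding affinity to Adrenergic receptor alpha-1 (Rattus norvegicus), read by radioligand binding; on this read-out lower numbers stand for stronger inhibition and higher numbers for weaker inhibition: > 10000 nM, a limit of the assay.
Compound 2, `O=C(O)c1cccc(CN2CCC(c3cn(Cc4ccoc4)c4ccccc34)CC2)c1`, in this assay: > 10000 nM, a limit of the assay.

Among the compounds with values here, compound 1 stands only at a limit in this assay, and the single measured step, a step that the two limits leave unreadable from compound 1 to compound 2, cannot be read because of the limit of > 10000 nM in this assay, at which 2 of the 2 values shown sit. Compound 3, `CCCCn1cc(C2CCN(Cc3ccc(OC)c(C(=O)O)c3)CC2)c2ccccc21`, differs from compound 1 by methoxy in place of hydrogen on an aromatic carbon. Within the data shown here, no measured step bears on this change, and compound 1 gives no number to start from. Compound 3 is therefore expected to remain at the limit, with an estimate of 20000 nM, ranging from 5000 nM to 80000 nM. The expected step is a step that the limit leaves unreadable from compound 1 to compound 3.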

Compound 3, half-maximal inhibitory concentration: > 10000 nM
Compound 3: only a limit was reported; the forecaster's own chance of this, stated with the estimate: 80%; the middle value is on the limit's open side.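

Compound 3 and compound 1 both stand only at a limit in this assay, so the step between them cannot be read: the limit of > 10000 nM in this assay, at which 3 of the 3 values shown sit.

On these data alone, the actual strength of compound 1, compound 2 and compound 3, and whether methoxy changes it at all, remains open.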